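Phenethyl in place of naphthalen-1-yl on the sulfur

The source may report more compounds than this note shows. Statements on the series, on what has been measured and on what is new or still open speak of the compounds shown alone.

In a functional assay on HeLa cells (Homo sapiens) for inhibition, read by CCK-8 assay, with a stated time of 72 h, tested at 8 uM (on this read-out lower numbers stand for less inhibition of growth and higher numbers for more inhibition of growth at the one concentration tested), compound 1 (`Nc1ccccc1NC(=O)/C=C/c1ccc(CSc2ccc(C(F)(F)F)cn2)cc1`) gives 6.82% and compound 2 (`Nc1ccccc1NC(=O)/C=C/c1ccc(CSc2cccc3ccccc23)cc1`) gives 22.1% as the higher of the two numbers. Compound 3 (`Nc1ccccc1NC(=O)/C=C/c1ccc(CSCCc2ccccc2)cc1`) carries phenethyl in place of naphthalen-1-yl on a sulfur. Within the data shown here, only one measured step bears on this change, at the same sulfur (a number 15.3 percentage points higher from compound 1 to compound 2 (beyond the scatter)), and no measured compound carries phenethyl. A step smaller than that one is therefore expected, pointing downward and probably within the scatter (a number 6.1 percentage points lower from compound 2 to compound 3 (within the scatter)). Compound 3 is estimated at 16% (expected range 4% to 32%).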

Compound 3, percent growth inhibition at one concentration: 3.57%
The estimate for compound 3 lay 12.4 percentage points above the measured number, outside the stated range (below it).
By their numbers in this assay, from the lowest: compounds 3 and 1 (each within the scatter of the next); then compound 2.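

In this assay, phenethyl on the sulfur does not keep the number of compound 2, with a number 18.5 percentage points lower from compound 2 to compound 3 (beyond the scatter) as the step, so among these three compounds only naphthalen-1-yl stands apart. Phenethyl and 5-(trifluoromethyl)pyridin-2-yl are not separated, with a number 3.3 percentage points lower from compound 1 to compound 3 (within the scatter) as the step within the scatter. No measurement available here explains either step.

From the compounds shown here alone, it remains open whether the second aromatic ring of naphthalen-1-yl or the chain in phenethyl matters more. Naphthalen-2-yl, phenyl or benzyl on the sulfur would bear on that question.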